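This account rests on a few compounds, and the source may have more. Where it says the series, first, only, none or still open, it means among the compounds named here.

Measured compounds:
compound 1 `COc1ccc(/C=N/c2c(C)n(C)n(-c3ccccc3)c2=O)cc1` with 575000000 nM
compound 2 `COc1cccc(/C=N/c2c(C)n(C)n(-c3ccccc3)c2=O)c1` with 933000000 nM

Both were tested in a functional assay on HCT-116 cells (Homo sapiens) for cytotoxicity, read by MTT assay, with a stated time of 72 h; on this read-out higher numbers stand for weaker inhibition and lower numbers for stronger inhibition. Among the measured compounds shown here, of these two numbers compound 2 holds the highest, and its only neighbour is compound 1, whose step a 1.6-fold higher number from compound 1 to compound 2 (0.21 log units; within the scatter) lies within the scatter, so the two cannot be told apart on this read-out. Compound 3 `Cc1c(/N=C/c2ccccc2)c(=O)n(-c2ccccc2)n1C` has not been measured. It differs from compound 2 by hydrogen in place of methoxy on an aromatic carbon, on an aromatic carbon of a six-membered aromatic ring of carbon only. For the measured compounds named here, no measured pair removes the methoxy altogether; the only step at hand, a 1.6-fold higher number from compound 1 to compound 2 (0.21 log units; within the scatter), moved that group to another place on the ring without a change beyond the scatter. The methoxy thus seems to matter little here, though this rests on a single pair. The expected step is a 1.2-fold lower number from compound 2 to compound 3 (0.07 log units; within the scatter), no change beyond the scatter. The estimate for compound 3 in this assay is 800000000 nM, with a range from 300000000 nM to 2100000000 nM.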

Compound 3, half-maximal inhibitory concentration: 589000000 nM
Beside the measured number, compound 3's estimate is 1.4-fold (0.13 log units) above it; the range from low to high includes it.
By their numbers in this assay, from the lowest: compounds 1, 3 and 2 (each within the scatter of the next).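

The methoxy can now be taken away altogether, not just moved, and the 3-methoxyphenyl to phenyl change gives a 1.6-fold lower number from compound 2 to compound 3 (0.20 log units; within the scatter). Removing it from the 4-methoxyphenyl compound gives a 1.0-fold higher number from compound 1 to compound 3 (0.01 log units; within the scatter), so both removals stay within the scatter. In this assay, the ring with a methoxy at either place and the ring with only hydrogen therefore cannot be told apart, which turns the earlier hint from a single pair into a finding shared by all three compounds; nothing available here offers an explanation for this.

As far as these compounds go, it remains open whether an amine or a carboxylic acid on this aromatic ring would give a step beyond the scatter. The same question stands for a longer chain, such as an ethoxy group, in place of the methoxy.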